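The source may hold more compounds than are shown below. What is called first, only, known or untested is meant among the compounds shown, and "the series" means these compounds.

In a functional assay on SK-OV-3 cells (Homo sapiens) for cytotoxicity, read by sulforhodamine B assay, with a stated time of 48 h (a higher number here means a weaker inhibitor, a lower number a stronger inhibitor), compound 1 `O=c1cc(-c2ccccc2)oc2cc(OCCCCNc3nc4ccc([N+](=O)[O-])cc4s3)cc(O)c12` gives 41.4 ug/mL and compound 2 `O=c1cc(-c2ccccc2)oc2cc(OCCCCNc3nc4ccc(I)cc4s3)cc(O)c12` gives 56.4 ug/mL. Going by the values given here, these two values lie within the scatter of each other, so compound 2 stands level with the only other measured compound. Compound 3 `O=c1cc(-c2ccccc2)oc2cc(OCCCCNNc3nc4ccccc4s3)cc(O)c12` differs from compound 2 at one place: (1,3-benzothiazol-2-yl)amino in place of 6-iodo-1,3-benzothiazol-2-yl on an amine nitrogen. In words, it carries (1,3-benzothiazol-2-yl)amino in place of 6-iodo-1,3-benzothiazol-2-yl on an amine nitrogen. Among the compounds with values here, only one measured step bears on this change. Putting iodo in place of nitro on an aromatic carbon gave a 1.4-fold higher number from compound 1 to compound 2 (0.13 log units; within the scatter), so that swap of groups stayed within the scatter. Within the data shown here, no measured compound carries the entering group, so the evidence is thin, and no shift beyond the scatter is expected in this assay. The expected change is a 1.3-fold lower number from compound 2 to compound 3 (0.10 log units; within the scatter). Compound 3 is estimated at about 45 ug/mL, with a range of 20 ug/mL to 100 ug/mL.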

Compound 3, half-maximal inhibitory concentration: 51.7 ug/mL
The estimate for compound 3 lay 1.1-fold (0.06 log units) below the measured number; low and high end bracket the measured number.
By their numbers in this assay, from the lowest: compounds 1, 3 and 2 (each within the scatter of the next).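

In this assay, the swap of 6-iodo-1,3-benzothiazol-2-yl for (1,3-benzothiazol-2-yl)amino on the amine nitrogen gave a 1.1-fold lower number from compound 2 to compound 3 (0.04 log units; within the scatter) and the matching swap from the nitro compound gave a 1.2-fold higher number from compound 1 to compound 3 (0.10 log units; within the scatter) so this position tolerated a change larger than a ring substituent alone without leaving the scatter. The entering group brings a second chain nitrogen and a hydrogen-bond donor and also lacks the ring iodine, and these differences arrive together in a single step, so the compounds cannot separate them. Nothing measured here accounts for this result.

The compounds shown leave open what the plain 1,3-benzothiazol-2-yl amine, without the extra nitrogen, would give. They also leave open whether a longer chain or an amide at this nitrogen would move the number beyond the scatter.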